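Pyridin-2-yl in Place of Phenyl on the Shared Core

The source may report more compounds than this note shows. Statements on the series, on what has been measured and on what is new or still open speak of the compounds shown alone.

Measured compounds:
compound 1 `Cc1cc2c(c(N)nn2C)c(=O)[nH]1`: 4%
compound 2 `Cn1nc(N)c2c(=O)[nH]c(-c3ccccc3)cc21`: 9%

In an assay on isolated protein for inhibition of ribosomal protein S6 kinase alpha-5 (Homo sapiens), read by mobility shift assay, tested at 30 uM (a lower number here means less inhibition, a higher number more inhibition at the concentration tested (going by the name of the read-out)), compound 1 gives 4%, and compound 2 gives 9%. Of the two numbers, compound 2 holds the larger one, yet the step of a number 5 percentage points higher from compound 1 to compound 2 (within the scatter) lies within the scatter, so the two compounds cannot be told apart on these data.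

Compound 3 `Cn1nc(N)c2c(=O)[nH]c(-c3ccccn3)cc21` has not yet been measured. It differs from compound 2 in a single place: pyridin-2-yl in place of phenyl on an aromatic carbon.

Among the compounds with values here, only one measured step exists, a number 5 percentage points higher from compound 1 to compound 2 (within the scatter), and it concerns phenyl in place of methyl rather than pyridin-2-yl in place of phenyl. It did not move the read-out beyond the scatter, and both compounds sit low on the scale. Within the data shown here, there is no measured step for the change from compound 2 to compound 3, so the expectation rests on the low level of compound 2 alone. For compound 3 the step expected is no change at the digits printed from compound 2 to compound 3 (within the scatter), meaning none beyond the scatter. Compound 3 is therefore estimated at 9%, with a range from 0% to 20%.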

Compound 3, a percentage reported as inhibition, at one concentration (the size of the read-out at that concentration, not a potency): -4%
Beside the measured number, compound 3's estimate is 13 percentage points above it, and the stated range ends above it.
By their numbers in this assay, from the lowest: compounds 3, 1 and 2 (each within the scatter of the next, the first and the last beyond it).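

Within the data shown here, replacing phenyl with pyridin-2-yl is the first change at this aromatic carbon to move the read-out beyond the scatter: in this assay there is a number 13 percentage points lower from compound 2 to compound 3 (beyond the scatter), so exchanging a single ring carbon for a nitrogen can be detected here, although the step is modest and compound 3 gives -4%. The comparison with the small methyl group tells a different story, since a number 8 percentage points lower from compound 1 to compound 3 (within the scatter) leaves pyridin-2-yl and methyl impossible to tell apart at this position, and only phenyl and pyridin-2-yl are separated. Nothing available explains why the ring nitrogen lowers the number in this way.

From the compounds shown here alone, all three compounds remain low on the scale, so it is still open whether any group on this carbon can raise inhibition clearly above this level. Pyridin-3-yl and pyridin-4-yl would show whether the place of the ring nitrogen matters, while an amine or a carboxylic acid on the phenyl ring would test whether added groups there change the read-out at all.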